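Pyridin-4-yl for phenyl on the pyrrolopyridine arm

The compounds below may be only part of what the source reports. "The series", "measured", "known", "first", "only" and "open" are said of these compounds alone.

Two compounds of the series carry numbers in a functional assay on T47D cells (Homo sapiens) for inhibition, read by sulforhodamine B assay, with a stated time of 72 h; a lower number here means a stronger inhibitor of growth, a higher number a weaker inhibitor of growth. Compound 1 `O=S(=O)(Nc1cc(-c2cnc3[nH]cc(-c4ccccc4)c3c2)cnc1Cl)c1ccccc1` gives 7720 nM and stands as the highest of the two values. Compound 2 `O=S(=O)(Nc1cc(-c2cnc3[nH]nc(-c4ccncc4)c3c2)cnc1Cl)c1ccccc1` differs from compound 1 both in the fused core and in the aryl group on it, and in this assay compound 2 gives 520 nM; the gap between the two values is beyond the scatter, but with two changes at once the aryl part of it cannot be separated from the core part.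

Compound 3 `O=S(=O)(Nc1cc(-c2cnc3[nH]cc(-c4ccncc4)c3c2)cnc1Cl)c1ccccc1` keeps the core of compound 1 and makes only the aryl change: pyridin-4-yl in place of phenyl on an aromatic carbon. Among the measured compounds shown here, no step between measured compounds isolates this change. The expectation for compound 3 is a step down in this assay, of a size beyond the scatter but smaller than the whole gap from compound 1 to compound 2, since that gap also carries the core change. Compound 3 is therefore estimated at 1800 nM, with a range from 500 nM to 6000 nM. The expected step is a 4.3-fold lower number from compound 1 to compound 3 (0.63 log units; beyond the scatter).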

Compound 3, concentration for 50% growth inhibition: 1500 nM
Compound 3: the middle estimate sits 1.2-fold (0.08 log units) above what was measured; measured number inside the range.
By their numbers in this assay, from the lowest: compound 2; then compound 3; then compound 1.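

Pyridin-4-yl in place of phenyl on this aromatic carbon, with the core of compound 1 held fixed, gives in this assay a 5.1-fold lower number from compound 1 to compound 3 (0.71 log units; beyond the scatter) and so shows that this position responds to a swap that leaves the heavy-atom count unchanged and brings in a hydrogen-bond acceptor. The aryl part of the earlier two-change comparison can now be read alone, and compound 3 also shares its pyridin-4-yl with compound 2, the two differing only in the fused core: compound 3 stands at 1500 nM and compound 2 at 520 nM in this assay so the lower number of compound 2 is not explained by the aryl swap alone. Nothing measured here gives a reason for the step.

As far as these compounds go, whether the same swap gives a step of similar size on the fused core of compound 2 remains open, as a phenyl partner on that core would be needed to read it. Also open, from the compounds shown here alone, is whether the ring nitrogen must sit as in pyridin-4-yl, or whether pyridin-3-yl, pyrimidin-5-yl or a phenyl bearing an aminomethyl group would lower the number further.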